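Second fluorine on the benzyl group of compound 1

This account rests on a few compounds, and the source may have more. Where it says the series, first, only, none or still open, it means among the compounds named here.

Compound 1 `OC[C@H]1O[C@@H](n2cnc3c(NCc4cccc(F)c4)ncnc32)[C@H](O)[C@@H]1O` carries a 3-fluorophenyl on a saturated chain carbon bound to a nitrogen on an aromatic ring. In a functional assay on HOS cells (Homo sapiens) for antiproliferative activity, with a stated time of 72 h (a higher number here means a weaker inhibitor, a lower number a stronger inhibitor), compound 1 gives only a limit of the assay, > 166000 nM. Compound 3 `COc1ccc(CNc2ncnc3c2ncn3[C@@H]2O[C@H](CO)[C@@H](O)[C@H]2O)c(OC)c1` likewise gives only a limit, > 166000 nM. Compound 2 `OC[C@H]1O[C@@H](n2cnc3c(NCc4ccc(F)cc4)ncnc32)[C@H](O)[C@@H]1O`, by contrast, gives a number, 13200 nM. For the measured compounds named here, the only measured change that bears on the new compound is an at least 12-fold lower number from compound 1 to compound 2 (1.09 log units; beyond the scatter); the change an at least 12-fold higher number from compound 2 to compound 3 (1.09 log units; beyond the scatter) runs the other way, back to the limit. Compound 4 `OC[C@H]1O[C@@H](n2cnc3c(NCc4ccc(F)cc4F)ncnc32)[C@H](O)[C@@H]1O` differs from compound 1 by 2,4-difluorophenyl in place of 3-fluorophenyl on a saturated chain carbon bound to a nitrogen on an aromatic ring. The 2,4-difluorophenyl of compound 4 resembles the 4-fluorophenyl of compound 2 more closely than it resembles the 3-fluorophenyl of compound 1, so compound 4 is expected to behave more like compound 2. A step of an at least 8.3-fold lower number from compound 1 to compound 4 (0.91 log units; beyond the scatter) is therefore expected, since compound 2 gives 13200 nM. For compound 4 the estimate in this assay is 20000 nM, within a range from 5000 nM to 166000 nM.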

Compound 4, half-maximal inhibitory concentration: > 166000 nM
Compound 4 ended at the assay's limit; the forecaster's own chance of this, stated with the estimate: 30%; middle value at least 8.3-fold (0.91 log units) away from the limit.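

Fluoro in place of hydrogen on an aromatic carbon gives an at least 12-fold higher number from compound 2 to compound 4 (1.09 log units; beyond the scatter) in this assay, so a single added fluorine on the 4-fluorophenyl of compound 2 is enough to lose the only measurable value in this set. Compound 4 gives > 166000 nM, which is a limit of the assay and not a number. Of the groups shown, only the 4-fluorophenyl of compound 2 gives a number, and the steps to compound 4 from compound 1 and from compound 3 cannot be read, with both ends of each step sitting at one value: the limit of > 166000 nM in this assay, at which 3 of the 4 values shown sit.

From the compounds shown here alone, how compound 1, compound 3 and compound 4 rank against each other stays open. Also open, going by these compounds, is whether 4-chlorophenyl or 4-methoxyphenyl in place of the 4-fluorophenyl of compound 2 would still give a number.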